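Amino in Place of Chloro on a Purine-Type Core

A few compounds are considered here, and "the series" means these few. Any claim that something is new, unique, unknown or untested is made for them only; others in the source may bear on it.

Three compounds were tested in a functional assay on MDA-MB-231 cells (Homo sapiens) for cytotoxicity, read by sulforhodamine B assay, with a stated time of 48 h; on this read-out lower numbers stand for higher toxicity in this test and higher numbers for lower toxicity in this test. Compound 1 `ClCc1ccccc1Cn1cnc2c(Cl)nc(Cl)nc21` gives 3980 nM, the lowest of the three numbers. Compound 3 `ClCc1ccc(Cn2cnc3c(Cl)nc(Cl)nc32)cc1` gives 7240 nM, a value that lies within the scatter of compound 1, so the two cannot be placed in any order. Among the compounds with values here, compound 2 `ClCc1ccccc1Cn1cnc2ncnc(Cl)c21` gives 25100 nM, which stands well beyond the scatter above compound 1; compound 2 also lacks one of the two chloro groups on the core that compound 1 carries, but no single step connects these two structures, and what the pair shows is only the gap between its two values.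

Compound 4 `Nc1nc(Cl)c2ncn(Cc3ccccc3CCl)c2n1` has not yet been measured in this assay. It differs from compound 1 by amino in place of chloro on an aromatic carbon, an amino in place of chloro on an aromatic carbon. Within the data shown here, no step between measured compounds involves this change, so any expectation rests on the general picture: the higher number of compound 2 at 25100 nM hints that the core of compound 1 does not tolerate every alteration, yet the amino group is a different substitution than a bare ring position. A moderate rise in the number, beyond the scatter, is expected for a 2.5-fold higher number from compound 1 to compound 4 (0.40 log units; beyond the scatter). For compound 4 the estimate is 10000 nM, with a range from 3000 nM to 35000 nM.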

Compound 4, concentration lethal to 50% of the cells: 63100 nM
Compound 4: the middle estimate sits 6.3-fold (0.80 log units) below what was measured, and the stated range ends below it.
By their numbers in this assay, from the lowest: compounds 1 and 3 (each within the scatter of the next); then compound 2; then compound 4.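

In this assay the exchange of chloro for amino on this aromatic carbon, between two ring nitrogen atoms, is a large one, with a 16-fold higher number from compound 1 to compound 4 (1.20 log units; beyond the scatter) and beyond anything the usual scatter would account for. It is the first change in a single place among the compounds shown, so a higher number can now be tied to this one position on the core of compound 1 rather than read only as a gap between structures that differ in more than one place. The count changes as well, with amino bringing a hydrogen-bond donor and a hydrogen-bond acceptor that chloro did not, but no measurement on hand says what lies behind the step.

Still open, from the compounds shown here alone, is whether the step follows from the loss of chloro at this position or from the arrival of amino in particular, a question that a methylamino, methoxy or fluoro group in the same place would help to separate. Also open, going by these compounds, is whether the same exchange would carry over to compound 3, which holds the same two chloro groups on the core.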